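A few compounds are considered here, and "the series" means these few. Any claim that something is new, unique, unknown or untested is made for them only; others in the source may bear on it.

In a functional assay on PANC-1 cells (Homo sapiens) for cytotoxicity, read by MTT assay, with a stated time of 48 h (a lower number here means a stronger inhibitor, a higher number a weaker inhibitor), compound 1 `CC(C)=CCC/C(C)=C/CC/C(C)=C/CSc1ccccc1C(=O)NCCN` gives > 50000 nM. That reading is a limit of the assay and not a number, so the starting point of this step is open on one side.

Compound 3 `CC(C)=CCC/C(C)=C/CC/C(C)=C/CSc1ccccc1C(=O)NCCCCCCN` differs from it by 4-aminobutyl in place of amino on a saturated chain carbon, two bonds along the chain from an amide-type nitrogen. The core of compound 1 stays unchanged.

Within the data shown here, one measured step bears on this change. Compound 2 `CC(C)=CCC/C(C)=C/CC/C(C)=C/CSc1ccccc1C(=O)NCCCCCN`, with 3-aminopropyl at the same place, gives 7560 nM. The step is an at least 6.6-fold lower number from compound 1 to compound 2 (0.82 log units; beyond the scatter), and its size is only a bound. A single step sets no trend, so any extrapolation is loose.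

The longer chain of compound 3 is expected to move this assay in the same direction, towards a lower number, and to land near compound 2 at 7560 nM. The expected step is an at least 10-fold lower number from compound 1 to compound 3 (1.00 log units; beyond the scatter). For compound 3 the estimated value is 5000 nM, with an expected range of 2000 nM to 14000 nM.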

Compound 3, half-maximal inhibitory concentration: 8690 nM
Beside the measured number, compound 3's estimate is 1.7-fold (0.24 log units) below it; measured number inside the range.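

In this assay, the second chain extension also gives a lower number than compound 1, with an at least 5.7-fold lower number from compound 1 to compound 3 (0.75 log units; beyond the scatter), so 3-aminopropyl and 4-aminobutyl at this place now point the same way. Adding aminomethyl at the place five bonds along the chain from an amide-type nitrogen gives a 1.1-fold higher number from compound 2 to compound 3 (0.06 log units; within the scatter), so compound 2 and compound 3 cannot be told apart in this assay, and the further extension brings no measurable shift. The steps away from compound 1 remain bounds only, as the reading for compound 1 is a limit of the assay and not a number: the limit of > 50000 nM in this assay, at which 1 of the 3 values shown sits.

Still open, going by these compounds, is whether a chain longer than that of compound 3 would keep the reading level or move it in either direction, and where between compound 1 and compound 2 the shift sets in. Also open, on these data alone, is whether the amine itself matters at this place, which a dimethylamine, a hydroxyl or a carboxylic acid in place of the amino group on the same chain would address.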